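The source may report more compounds than this note shows. Statements on the series, on what has been measured and on what is new or still open speak of the compounds shown alone.

Measured so far:
- compound 1, `O=C(O)c1cc(-c2cccc(COc3ccc4c(=O)n(CC5CC5)sc4c3)c2)ccc1Cl` — 2480 nM
- compound 2, `O=C1c2ccc(OCc3cccc(-c4ccccc4)c3)cc2CN1C1CCCC1` — > 5000 nM
- compound 3, `CN(C)C(=O)c1cc(-c2cccc(COc3ccc4c(=O)n(C5CCCC5)sc4c3)c2)ccc1Cl` — 980 nM

These three compounds were tested in an assay on HEK293 cells for positive allosteric modulation of metabotropic glutamate receptor 2 (Rattus norvegicus), read by thallium flux; a lower number here means that less compound is needed, a higher number that more compound is needed for the effect. Compound 1 gives 2480 nM. Where compound 1 carries a carboxylic acid, compound 3 carries a dimethylamide, and in this assay compound 3 gives 980 nM. Compound 2 stands apart: its result is a limit of the assay, > 5000 nM, so no number is known for it, only that it sits at the limit of > 5000 nM in this assay, at which 1 of the 3 values shown sits.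

Compound 4, `Cc1ccc(C(=O)O)cc1-c1cccc(COc2ccc3c(c2)CN(C2CCCC2)C3=O)c1`, follows from compound 2 by one change: 5-carboxy-2-methylphenyl in place of phenyl on an aromatic carbon. The other two compounds, compound 1 and compound 3, each carry a substituted aryl group bearing a carboxylic acid or an amide rather than a bare phenyl, and both give measurable values in this assay. On that basis the step from compound 2 to compound 4 is expected to move toward a lower number, though the size is uncertain because compound 2 gives only > 5000 nM. The estimate for compound 4 is 3000 nM, in the range 1000 nM to 9000 nM, a step of an at least 1.6-fold lower number from compound 2 to compound 4 (0.22 log units; that floor lies within the scatter).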

Compound 4, half-maximal effective concentration: 110 nM
For compound 4 the middle estimate is 27-fold (1.44 log units) above the measured one; the measured number lies below the stated range.
By their numbers in this assay, from the lowest: compound 4; then compound 3; then compound 1. At a limit, above all of these: compound 2.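

In this assay, putting 5-carboxy-2-methylphenyl in place of phenyl on an aromatic carbon, meta to a large group, gives an at least 45-fold lower number from compound 2 to compound 4 (1.65 log units; beyond the scatter), a large step well beyond the scatter. Going by these compounds alone, this is the first comparison here of two compounds that differ in only one place, so it ties a change in the number to this position, which compounds 1 and 3 could not do. The step is only a floor, as compound 2 has a limit and not a number: the limit of > 5000 nM in this assay, at which 1 of the 4 values shown sits.

The carboxylic acid and the methyl enter together as one group, so the compounds shown do not tell how much of the step belongs to either alone. On these data alone, how a nitrile or an amine in the same place would compare also remains open.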